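The source may hold more compounds than are shown below. What is called first, only, known or untested is meant among the compounds shown, and "the series" means these compounds.

Of the compounds shown here, three bearing the same cyclic amide core have been tested in an assay on isolated protein for inhibition of Polyunsaturated fatty acid 5-lipoxygenase (Homo sapiens); a higher number here means a weaker inhibitor, a lower number a stronger inhibitor. Compound 1 `Cc1cccc(N2CCCC(=O)N2)c1` gives 3400 nM, compound 2 `CCc1ccccc1N1CCCC(=O)N1` gives 39000 nM, and compound 3 `CCc1ccc(N2CCCC(=O)N2)cc1` gives 125000 nM. Compound 2 therefore holds the second-highest number of the three, sitting between compound 1 and compound 3, with both gaps beyond the usual scatter. Compound 4 `COc1ccccc1N1CCCC(=O)N1` differs from compound 2 by methoxy in place of ethyl on an aromatic carbon. Within the data shown here, no measured pair shows this exchange, so the direction is uncertain; the step from compound 2 to compound 4 is expected to be small, a 1.3-fold lower number from compound 2 to compound 4 (0.11 log units; within the scatter), and may fall within the scatter. Compound 4 is therefore estimated at 30000 nM in this assay, within a range from 8000 nM to 120000 nM.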

Compound 4, half-maximal inhibitory concentration: 204000 nM
Beside the measured number, compound 4's estimate is 6.8-fold (0.83 log units) below it; measured number outside the range, above it.
By their numbers in this assay, from the lowest: compound 1; then compound 2; then compounds 3 and 4 (each within the scatter of the next).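

Methoxy in place of ethyl on this aromatic carbon, ortho to a group of 7 heavy atoms, gives a 5.2-fold higher number from compound 2 to compound 4 (0.72 log units; beyond the scatter) in this assay. Among these compounds, both groups hold 2 heavy atoms, so at this position the count of heavy atoms alone does not set the number, which the earlier compounds, with only carbon groups on the aromatic ring, could not show. Nothing available explains this rise. Still open, on these data alone, is how an amine or a fluorine atom on this same carbon would behave, and whether the same exchange moves the number the same way at other carbons of the ring.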